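This account rests on a few compounds, and the source may have more. Where it says the series, first, only, none or still open, it means among the compounds named here.

Three compounds here carry a measured number. In an assay on HEK293 cells for antagonist activity at P2X purinoceptor 7 (Homo sapiens), read by fluorescence, with a stated time of 2 h (on this read-out higher numbers stand for weaker inhibition and lower numbers for stronger inhibition), compound 1 `CCN(CC)C(=O)c1cccc(S(=O)(=O)Oc2ccc(-c3cncn3C3CCN(C(=O)c4ccc(Cl)c(C(F)(F)F)c4)CC3)cc2)c1` gives 202 nM. In this assay compound 2 `O=C(c1ccc(Cl)c(C(F)(F)F)c1)N1CCC(n2cncc2-c2ccc(OS(=O)(=O)c3cccc4cnccc34)cc2)CC1` gives 45 nM, and compound 3 `COc1ccc(C(=O)N2CCC(n3cncc3-c3ccc(OS(=O)(=O)c4cccc5cnccc45)cc3)CC2)cc1` gives 77 nM. Among the three numbers compound 3 holds the second highest; its nearest neighbour is compound 2, since the step of a 1.7-fold higher number from compound 2 to compound 3 (0.23 log units; within the scatter) lies within the scatter, whereas compound 1 lies furthest away, with a gap that goes beyond the scatter.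

The unmeasured compound 4 `COc1ccc(C(=O)N2CCC(n3cncc3-c3ccc(OS(=O)(=O)c4cccc5cnccc45)cc3)CC2)cc1OC` differs from compound 3 by methoxy in place of hydrogen on an aromatic carbon. Going by the values given here, no measured step matches this change: the single step available, a 1.7-fold higher number from compound 2 to compound 3 (0.23 log units; within the scatter), exchanges one aryl group for another on the carbonyl carbon and tells nothing about adding a second methoxy to the same ring. In the absence of any bearing step, the change is expected to produce no movement beyond the scatter in this assay. The step this estimate means, a 1.0-fold higher number from compound 3 to compound 4 (0.02 log units; within the scatter), is expected to stay within the scatter. Compound 4 is therefore estimated at 80 nM, with a range from 35 nM to 185 nM.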

Compound 4, half-maximal inhibitory concentration: 259 nM
Estimate against measurement, compound 4: 3.2-fold (0.51 log units) below; measured number outside the range, above it.
By their numbers in this assay, from the lowest: compounds 2 and 3 (each within the scatter of the next); then compounds 1 and 4 (each within the scatter of the next).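

Adding methoxy on an aromatic carbon, ortho to a methoxy group and meta to a large group, gives in this assay a 3.4-fold higher number from compound 3 to compound 4 (0.53 log units; beyond the scatter) and is the first change shown at this position of the aryl group on the carbonyl carbon to go beyond the scatter. Exchanging the 4-chloro-3-(trifluoromethyl)phenyl group for 3,4-dimethoxyphenyl gives a 5.8-fold higher number from compound 2 to compound 4 (0.76 log units; beyond the scatter) and so also goes beyond the scatter, whereas the exchange for 4-methoxyphenyl, a 1.7-fold higher number from compound 2 to compound 3 (0.23 log units; within the scatter), does not. Nothing measured here accounts for this weaker inhibition.

As far as these compounds go, it remains open whether the change belongs to methoxy itself or to any group at this place, such as fluorine, hydroxy or an amine. From the compounds shown here alone, whether a longer chain such as ethoxy would behave alike also stays open.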